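The source may report more compounds than this note shows. Statements on the series, on what has been measured and on what is new or still open speak of the compounds shown alone.

Compound 1 `O=C(Nc1cccc(-n2cc(-c3ccncc3)c(-c3ccc(Cl)c(O)c3)n2)c1)Nc1cccc(C(F)(F)F)c1`: 1400 nM
Compound 2 `COc1cc(-c2nn(-c3cccc(NC(=O)c4cccc(C(F)(F)F)c4)c3)cc2-c2ccncc2)ccc1Cl`: 1630 nM

Both compounds were tested in a functional assay on M14 cells (Homo sapiens) for inhibition, read by sulforhodamine B assay, with a stated time of 48 h; a lower number here means a stronger inhibitor of growth, a higher number a weaker inhibitor of growth. In this assay, compound 2 gives 1630 nM, which lies within the usual scatter of compound 1. Compound 3 `COc1cc(-c2nn(-c3cccc(NC(=O)Nc4cccc(C(F)(F)F)c4)c3)cc2-c2ccncc2)ccc1Cl` carries (3-(trifluoromethyl)phenyl)amino in place of the 3-(trifluoromethyl)phenyl of compound 2, on a carbonyl carbon ((3-(trifluoromethyl)phenyl)amino in place of 3-(trifluoromethyl)phenyl on a carbonyl carbon). Going by the values given here, no measured pair isolates this change, so the expectation is of no shift beyond the scatter, as compound 1, which also carries this group, gives 1400 nM. The expected change is a 1.3-fold lower number from compound 2 to compound 3 (0.10 log units; within the scatter). Compound 3 is estimated at 1300 nM, with an expected range of 450 nM to 3500 nM.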

Compound 3, concentration for 50% growth inhibition: 754 nM
Compound 3: middle estimate off by 1.7-fold (0.24 log units), on the high side; measured number inside the range.
By their numbers in this assay, from the lowest: compounds 3, 1 and 2 (each within the scatter of the next, the first and the last beyond it).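

In this assay, going by these compounds alone, (3-(trifluoromethyl)phenyl)amino in place of 3-(trifluoromethyl)phenyl on a carbonyl carbon gives a 2.2-fold lower number from compound 2 to compound 3 (0.33 log units; beyond the scatter), the first direct reading of this change, and a modest one. Methyl in place of hydrogen on an oxygen on an aromatic ring gives a 1.9-fold lower number from compound 1 to compound 3 (0.27 log units; within the scatter), so that change does not separate these two compounds. Nothing given here explains either step. The compounds shown leave open whether a methylamino group in place of the amino link would keep the step from compound 2, and whether a nitrile in place of the trifluoromethyl would do so.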